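The source may hold more compounds than are shown below. What is called first, only, known or untested is meant among the compounds shown, and "the series" means these compounds.

For the measured compounds named here, compound 1 `COc1ccc(C2=NN(C3=NC(c4ccccc4)CS3)C(c3cccc4ccccc34)C2)cc1` is one of two compounds measured in a functional assay on HepG2 cells (Homo sapiens) for inhibition, read by CCK-8 assay, with a stated time of 48 h; on this read-out lower numbers stand for stronger inhibition and higher numbers for weaker inhibition. In this assay, going by the values given here, compound 1 gives 8740 nM, and compound 2 `Brc1ccc(C2=NN(C3=NC(c4ccccc4)CS3)C(c3cccc4ccccc34)C2)cc1` gives 15600 nM; the step of a 1.8-fold higher number from compound 1 to compound 2 (0.25 log units; within the scatter) shows that these two numbers cannot be told apart, so compound 1 stands on level ground with its only neighbour.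

Compound 3 `COc1ccc(C2=NN(C3=NC(=O)CS3)C(c3cccc4ccccc34)C2)cc1` changes compound 1 at the other end of the molecule: a group of 6 heavy atoms (3 carbon, 1 nitrogen, 1 oxygen, 1 sulfur; one five-membered non-aromatic ring with 2 hetero atoms) in place of a group of 11 heavy atoms (9 carbon, 1 nitrogen, 1 sulfur; one five-membered non-aromatic ring with 2 hetero atoms, one six-membered aromatic ring of carbon only), on an amine nitrogen in a ring. Among the compounds with values here, no measured step touches this position; the only step available, a 1.8-fold higher number from compound 1 to compound 2 (0.25 log units; within the scatter), concerns a swap on the 4-methoxyphenyl group and lies within the scatter, so it gives no direction for the present change. Without any step that bears on it, the number for compound 3 is expected to stay close to that of compound 1, with wide uncertainty, an expected step of a 1.6-fold higher number from compound 1 to compound 3 (0.20 log units; within the scatter). Compound 3 is therefore estimated at 14000 nM, within a range from 4000 nM to 50000 nM.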

Compound 3, half-maximal inhibitory concentration: 7850 nM
For compound 3 the middle estimate is 1.8-fold (0.25 log units) above the measured one, within the range that was stated.
By their numbers in this assay, from the lowest: compounds 3, 1 and 2 (each within the scatter of the next).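

On an amine nitrogen in a ring, the group of 11 heavy atoms gives way to the group of 6 heavy atoms, which has no six-membered aromatic ring of carbon only and brings in an oxygen. In this assay, the step of a 1.1-fold lower number from compound 1 to compound 3 (0.05 log units; within the scatter) shows that the two numbers cannot be told apart, so at this position the read-out does not separate a group with that aromatic ring from a smaller group without it. Nothing measured here offers an explanation for this result.

Going by these compounds, both groups seen at this position are five-membered non-aromatic rings with 2 hetero atoms, so the effect of an open chain, such as one ending in an amine or a carboxylic acid, remains open. Also open, on these data alone, is whether the same swap would read alike with a group other than naphthalen-1-yl on the core.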